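Furan for Benzofuran on Two Nucleoside Cores

A few compounds are considered here, and "the series" means these few. Any claim that something is new, unique, unknown or untested is made for them only; others in the source may bear on it.

Compound 1 `CNc1ncnc2c1c(-c1cc3ccccc3o1)cn2[C@@H]1O[C@H](CO)[C@@H](O)[C@H]1O` and compound 2 `CNc1ncnc2c1c(-c1ccco1)cn2[C@@H]1O[C@H](CO)[C@@H](O)[C@H]1O` share one core, while compound 3 `Nc1nc(N)c2c(-c3cc4ccccc4o3)cn([C@@H]3O[C@H](CO)[C@@H](O)[C@H]3O)c2n1` and compound 4 `Nc1nc(N)c2c(-c3ccco3)cn([C@@H]3O[C@H](CO)[C@@H](O)[C@H]3O)c2n1` share another; the difference between the two cores is not broken down here. In a functional assay on HepG2 cells (Homo sapiens) for antiproliferative activity, read by XTT assay, with a stated time of 72 h (a higher number here means a weaker inhibitor, a lower number a stronger inhibitor), compound 1 reaches only a limit, > 20000 nM. In this assay compound 2 gives 850 nM. The change furan-2-yl in place of 1-benzofuran-2-yl on an aromatic carbon therefore brings an at least 23-fold lower number from compound 1 to compound 2 (1.37 log units; beyond the scatter). In this assay compound 3 likewise reaches only a limit, > 20000 nM. The same change, (furan-2-yl in place of 1-benzofuran-2-yl on an aromatic carbon), is now made on the core of compound 3, at the same place. As far as these compounds go, how far compound 3 actually lies beyond the limit of > 20000 nM in this assay, at which 2 of the 3 values shown sit, is unknown, so the true starting point of the step is uncertain. The step is nevertheless expected to run in the same direction, estimated as an at least 3.3-fold lower number from compound 3 to compound 4 (0.52 log units; beyond the scatter), an expectation that rests on an at least 23-fold lower number from compound 1 to compound 2 (1.37 log units; beyond the scatter) seen on the other core. Compound 4 is expected to give roughly 6000 nM, with a likely range from 1500 nM to 20000 nM, and a fair chance that only a limit is reported again.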

Compound 4, half-maximal inhibitory concentration: > 20000 nM
Compound 4 was reported as a limit (the forecaster's own chance of this, stated with the estimate: 35%); middle value at least 3.3-fold (0.52 log units) away from the limit.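

Compound 3 and compound 4 both stand only as limits in this assay, so no step between them can be read from furan-2-yl in place of 1-benzofuran-2-yl on this core: the limit of > 20000 nM in this assay, at which 3 of the 4 values shown sit.

Still open, as far as these compounds go, is whether this change acts on the core of compound 3 as on the core of compound 1, where it brings an at least 23-fold lower number from compound 1 to compound 2 (1.37 log units; beyond the scatter).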